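From Methoxy to Ethyl: A Step Beneath the Limit

The compounds below may be only part of what the source reports. "The series", "measured", "known", "first", "only" and "open" are said of these compounds alone.

compound 1 `CCOC(=O)C1=C(Nc2ccccc2)S/C(=C\c2cccc(C(=O)O)c2)C1=O`: < 10%
compound 2 `CCOC(=O)C1=C(Nc2ccccc2)S/C(=C\c2ccccc2C(F)(F)F)C1=O`: < 10%
compound 3 `CCOC(=O)C1=C(Nc2ccc(OC)cc2)S/C(=C\c2ccc[nH]2)C1=O`: < 10%

Three compounds were tested in a functional assay on A549 cells (Homo sapiens) for inhibition, read by MTT assay, with a stated time of 72 h, tested at 10 uM; a higher number here means more inhibition at the concentration tested (going by the name of the read-out), a lower number less inhibition. In this assay compound 1 gives < 10%, which is a limit of the assay rather than a number. Compound 2 likewise gives < 10%, again a limit. Compound 3 also gives < 10%, once more a limit. Going by the values given here, all three values therefore sit at the same limit (the limit of < 10% in this assay, at which 3 of the 3 values shown sit), so no difference between them can be read, and there is no measured step between any pair.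

Compound 4 `CCOC(=O)C1=C(Nc2ccc(CC)cc2)S/C(=C\c2ccc[nH]2)C1=O` differs from compound 3 in one place: ethyl in place of methoxy on an aromatic carbon. The 4-methoxyphenyl of compound 3 becomes a 4-ethylphenyl in compound 4, the change sitting para to a large group.

Among the compounds with values here, since compound 3 rests at the limit and every measured compound shares that limit (the limit of < 10% in this assay, at which 3 of the 3 values shown sit), no step in this assay is expected beyond the scatter; the expected step is a step that the limit leaves unreadable from compound 3 to compound 4. Compound 4 is estimated to give 5% in this assay, within a range of 0% to 15%, and it is expected most likely to be reported only as a limit.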

Compound 4, a percentage reported as inhibition, at one concentration (the size of the read-out at that concentration, not a potency): 17.5%
Beside the measured number, compound 4's estimate is 12.5 percentage points below it; the measured number lies above the stated range.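

In this assay, compound 4 is the only compound shown that returns a number rather than a limit, giving 17.5%. This shows that a readable value can be reached on the shared core by changing only the group on an aromatic carbon para to a large group, from methoxy to ethyl, with a number at least 7.5 percentage points higher from compound 3 to compound 4 (that floor lies within the scatter). The true size of this step cannot be read, and the figure stays a floor, because compound 3 rests at a limit: the limit of < 10% in this assay, at which 3 of the 4 values shown sit.

The compounds shown leave open whether the change depends on the oxygen leaving or on the carbon entering, and whether a longer chain such as propyl, an amine or a carboxylic acid at the same place would also give a number. They also leave open whether ethyl at this place would give a readable value alongside the substituted benzylidene groups of compound 1 or compound 2, since compound 4 carries the pyrrole-bearing group of compound 3.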